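Clearance of sulfonyl quinolines: swapping the sulfonyl aryl

The compounds below may be only part of what the source reports. "The series", "measured", "known", "first", "only" and "open" are said of these compounds alone.

Measured compounds:
compound 1 `O=S(=O)(c1ccc(F)c(Cl)c1)c1cnc2c(F)cccc2c1-c1cccc(Cl)c1` 0.18 mL/min
compound 2 `O=S(=O)(c1ccc(F)c(Cl)c1)c1cnc2c(F)cccc2c1-c1ccccc1F` 1.39 mL/min
compound 3 `O=S(=O)(c1ccc(F)c(Cl)c1)c1cnc2c(F)cccc2c1-c1cccc(F)c1` 1.23 mL/min

In an ADME assay on microsomes from liver (Homo sapiens) for metabolic stability, tested at 2.5 uM (on this read-out lower numbers stand for slow clearance and higher numbers for fast clearance), compound 3 stands second highest of the three numbers; its nearest neighbour is compound 2, a 1.1-fold lower number from compound 2 to compound 3 (0.05 log units; within the scatter), while compound 1 lies furthest, a 6.8-fold higher number from compound 1 to compound 3 (0.83 log units; beyond the scatter). Compound 4 `O=S(=O)(c1cc(F)cc(F)c1)c1cnc2c(F)cccc2c1-c1cccc(F)c1` carries 3,5-difluorophenyl in place of 3-chloro-4-fluorophenyl on a sulfonyl sulfur. For the measured compounds named here, no measured step touches the group on the sulfonyl sulfur; the steps that are known, a 7.7-fold higher number from compound 1 to compound 2 (0.89 log units; beyond the scatter) and a 6.8-fold higher number from compound 1 to compound 3 (0.83 log units; beyond the scatter), both sit on an aromatic carbon of the other aryl. Going by the values given here, the only guidance is that fluoro in place of chloro there raised the number beyond the scatter. A similar but smaller move is therefore expected for compound 4, a 1.3-fold higher number from compound 3 to compound 4 (0.11 log units; within the scatter), which is expected to land at 1.6 mL/min in this assay, with a range of 0.6 mL/min to 4 mL/min.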

Compound 4, intrinsic clearance in a liver preparation (reported as CLH), per the amount of preparation that the assay uses: 1.18 mL/min
The estimate for compound 4 lay 1.4-fold (0.13 log units) above the measured number; the range from low to high includes it.
By their numbers in this assay, from the lowest: compound 1; then compounds 4, 3 and 2 (each within the scatter of the next).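

On the sulfonyl sulfur, in this assay, 3,5-difluorophenyl in place of 3-chloro-4-fluorophenyl gives a 1.0-fold lower number from compound 3 to compound 4 (0.02 log units; within the scatter) and so leaves the two compounds indistinguishable. Losing the chlorine here thus has no effect beyond the scatter, whereas fluoro in place of chloro on the other aryl gave a 6.8-fold higher number from compound 1 to compound 3 (0.83 log units; beyond the scatter) in the same read-out. No available evidence bears on this result. From the compounds shown here alone, whether the sulfonyl sulfur accepts a group other than a halogenated phenyl, such as a pyridine or an amine, remains open. So does whether 3,5-difluorophenyl behaves alike with the 3-chlorophenyl of compound 1 in place.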